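Changing the Ring on the Sulfonyl Sulfur

The source may hold more compounds than are shown below. What is called first, only, known or untested is meant among the compounds shown, and "the series" means these compounds.

Compound 3 `O=S(=O)(Nc1ccc(-c2nc3ccccc3o2)cc1)c1ccccc1F` was tested in an assay on cells for inhibition of HSP60/HSP10 (Homo sapiens), with a stated time of 60 min; on this read-out higher numbers stand for weaker inhibition and lower numbers for stronger inhibition. In this assay compound 3 reaches only the assay limit of > 100000 nM. Compound 1 `O=S(=O)(Nc1ccc(-c2nc3ccccc3o2)cc1)c1ccccc1O` likewise sits at the limit > 100000 nM. Compound 2 `O=S(=O)(Nc1ccc(-c2nc3ccccc3o2)cc1)c1ccc(Cl)s1` gives a measured number of 31000 nM. Both limits are the same one, (the limit of > 100000 nM in this assay, at which 2 of the 3 values shown sit). Compound 4 `O=S(=O)(Nc1ccc(-c2nc3ccccc3o2)cc1)c1ccc(Cl)c(Cl)c1` differs from compound 3 by 3,4-dichlorophenyl in place of 2-fluorophenyl on a sulfonyl sulfur. Going by the values given here, the steps of an at least 3.2-fold higher number from compound 2 to compound 3 (0.50 log units; beyond the scatter) and an at least 3.2-fold lower number from compound 1 to compound 2 (0.50 log units; beyond the scatter) show that exchanging the ring on the sulfonyl sulfur moves the number by at least a modest amount, and compound 2, with 5-chlorothiophen-2-yl, gave the only measured value. For compound 4 a move below the limit is therefore expected, an at least 2.5-fold lower number from compound 3 to compound 4 (0.39 log units; beyond the scatter). Compound 4 is estimated at 40000 nM, between 10000 nM and 200000 nM.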

Compound 4, half-maximal inhibitory concentration: 25000 nM
Beside the measured number, compound 4's estimate is 1.6-fold (0.20 log units) above it; the range from low to high includes it.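

Until now only 5-chlorothiophen-2-yl had given a measured number, and 3,4-dichlorophenyl shows that a phenyl ring on the sulfonyl sulfur can do so too, with an at least 4.0-fold lower number from compound 3 to compound 4 (0.60 log units; beyond the scatter) and an at least 4.0-fold lower number from compound 1 to compound 4 (0.60 log units; beyond the scatter). The two chlorine-bearing rings cannot be told apart in this assay: a 1.2-fold lower number from compound 2 to compound 4 (0.09 log units; within the scatter). The two larger steps are minimums, as compounds 1 and 3 each stand at a limit and not at a number: the limit of > 100000 nM in this assay, at which 2 of the 4 values shown sit.

Going by these compounds, whether a single chlorine on the phenyl ring would be enough stays open. So does whether an amine or a carboxylic acid in place of the chlorines would lower the number further.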